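The compounds below may be only part of what the source reports. "The series", "measured", "known", "first", "only" and "open" are said of these compounds alone.

Compound 2 `Cc1cccc(-c2cn3ccnc3c(-c3ccc4ncn(Cc5ccccc5)c4c3)n2)c1` was tested in a functional assay on EKVX cells (Homo sapiens) for inhibition, read by sulforhodamine B assay, with a stated time of 48 h, tested at 10 uM (on this read-out higher numbers stand for more inhibition at the one concentration tested (going by the name of the read-out) and lower numbers for less inhibition), and gave 22.3%, the lower of the two numbers recorded so far. Among the compounds with values here, its nearest neighbour, compound 1 `CCc1ccc(-c2cn3ccnc3c(-c3ccc4ncn(Cc5ccccc5)c4c3)n2)cc1`, gave 39.7% in this assay; the single step between them, a number 17.4 percentage points lower from compound 1 to compound 2 (beyond the scatter), is the only measured step available and lies beyond the scatter. The next compound, compound 3 `c1ccc(Cn2cnc3ccc(-c4nc(-c5cccc6ccccc56)cn5ccnc45)cc32)cc1`, has not yet been measured. It differs from compound 2 in one place, (naphthalen-1-yl in place of 3-methylphenyl on an aromatic carbon), so that the six-membered aromatic ring of carbon only with its methyl group gives way to two fused six-membered aromatic rings of carbon only at the same position. Within the data shown here, the step from compound 1 to compound 2 shows that exchanging the aromatic group at this position can move the number in this assay by a modest amount, but no measured pair covers a naphthalen-1-yl group, so the direction for compound 3 is uncertain. Compound 3 is therefore expected to return 36% in this assay, with a range from 16% to 56%, which would mean an estimated step of a number 13.7 percentage points higher from compound 2 to compound 3 (beyond the scatter), a modest rise that remains tentative.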

Compound 3, a percentage reported as inhibition, at one concentration (the size of the read-out at that concentration, not a potency): 24.6%
Compound 3: middle estimate off by 11.4 percentage points, on the high side, within the range that was stated.
By their numbers in this assay, from the lowest: compounds 2 and 3 (each within the scatter of the next); then compound 1.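

In this assay, naphthalen-1-yl in place of 3-methylphenyl on this aromatic carbon gives a number 2.3 percentage points higher from compound 2 to compound 3 (within the scatter), so a second six-membered aromatic ring of carbon only, and 10 heavy atoms where there were 7, do not separate these two compounds. The same group in place of 4-ethylphenyl gives a number 15.1 percentage points lower from compound 1 to compound 3 (beyond the scatter), so two different replacements of 4-ethylphenyl, one with a single ring and one with two, both stand apart from compound 1 while lying within the scatter of each other; the number therefore does not follow the ring count across these three compounds. Nothing measured on these compounds accounts for this pattern.

Compound 1 and compound 2 differ both in the length of the chain and in where it sits on the ring, so the compounds shown leave open which of the two sets compound 1 apart, a question that 4-methylphenyl and 3-ethylphenyl at this position would address. Also open, going by these compounds, is how this position responds to naphthalen-2-yl, or to a phenyl ring carrying an amine or a carboxylic acid.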